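The source may report more compounds than this note shows. Statements on the series, on what has been measured and on what is new or still open speak of the compounds shown alone.

Compound 1 `O=C(Nc1ccc2[nH]cc(C3CCN(CCCCCCN4CCC(c5c[nH]c6ccc(NC(=O)c7ccc(F)cc7)cc56)CC4)CC3)c2c1)c1ccc(F)cc1` joins two copies of the shared core through a saturated chain, and in an assay on CHO-K1 cells for displacement of a labelled ligand from 5-hydroxytryptamine receptor 1B (Homo sapiens), read by scintillation counting (on this read-out lower numbers stand for stronger inhibition and higher numbers for weaker inhibition), compound 1 gives 100 nM. Compound 2 `CCCCCCCCN1CCC(c2c[nH]c3ccc(NC(=O)c4ccc(F)cc4)cc23)CC1` carries a single core with a long saturated chain on the ring amine. In this assay compound 2 reaches only the limit > 1000 nM. Compound 3 `O=C(Nc1ccc2[nH]cc(C3CCN(CCN4CCCCC4)CC3)c2c1)c1ccc(F)cc1` likewise sits at a limit, > 1000 nM. The step from compound 2 to compound 3 a step that the two limits leave unreadable from compound 2 to compound 3 cannot be sized because of the limit of > 1000 nM in this assay, at which 2 of the 3 values shown sit. Compound 4 `CN(C)CCCN1CCC(c2c[nH]c3ccc(NC(=O)c4ccc(F)cc4)cc23)CC1` differs from compound 3 by (dimethylamino)methyl in place of piperidin-1-yl on a saturated chain carbon, two bonds along the chain from an amine nitrogen in a ring. Within the data shown here, no measured step bears directly on this change, and the single-core compounds both sit at the limit, so compound 4 is expected to stay near it. The step expected a step that the limit leaves unreadable from compound 3 to compound 4 is therefore small. Compound 4 is estimated at 3000 nM, between 800 nM and 10000 nM.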

Compound 4, inhibition constant: > 1000 nM
Compound 4: only a limit was reported (the forecaster's own chance of this, stated with the estimate: 75%); the middle value lies beyond the limit too.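

No step from compound 2 or compound 3 to compound 4 can be read, because all three compounds sit at a limit: the limit of > 1000 nM in this assay, at which 3 of the 4 values shown sit.

From the compounds shown here alone, how far compound 2, compound 3 and compound 4 truly differ in this assay remains open.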